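Ethyl for Methyl on the Ring Nitrogen: Cytotoxicity Outlook

The source may report more compounds than this note shows. Statements on the series, on what has been measured and on what is new or still open speak of the compounds shown alone.

In an ADME assay on HEK-293T cells (Homo sapiens) for cytotoxicity, read by MTT assay, with a stated time of 48 h (on this read-out lower numbers stand for higher toxicity in this test and higher numbers for lower toxicity in this test), compound 1 `CN1CCN(CCC(=O)N[C@@H]2C[C@H]3CC[C@]2(C)C3(C)C)CC1` gives 486000 nM. Compound 2 `CN1CCN(CCCC(=O)N[C@@H]2C[C@H]3CC[C@]2(C)C3(C)C)CC1` gives 475000 nM in this assay; the difference between the two cores is not broken down here. Compound 3 `CCN1CCN(CCC(=O)N[C@@H]2C[C@H]3CC[C@]2(C)C3(C)C)CC1` differs from compound 1 by methyl in place of hydrogen on a saturated chain carbon bound to an amine nitrogen in a ring. In this assay compound 3 gives 565000 nM, so that a 1.2-fold higher number from compound 1 to compound 3 (0.07 log units; within the scatter). Compound 4 `CCN1CCN(CCCC(=O)N[C@@H]2C[C@H]3CC[C@]2(C)C3(C)C)CC1` has not yet been measured; it differs from compound 2 by methyl in place of hydrogen on a saturated chain carbon bound to an amine nitrogen in a ring, the same change as that from compound 1 to compound 3. Because a 1.2-fold higher number from compound 1 to compound 3 (0.07 log units; within the scatter), the corresponding step is expected to be equally small, namely a 1.2-fold higher number from compound 2 to compound 4 (0.06 log units; within the scatter). For compound 4 in this assay the expected value is 550000 nM, with a likely range from 300000 nM to 1000000 nM.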

Compound 4, half-maximal cytotoxic concentration: 268000 nM
For compound 4 the middle estimate is 2.1-fold (0.31 log units) above the measured one; measured number outside the range, below it.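

Set on a second core, the change from 4-methylpiperazin-1-yl to 4-ethylpiperazin-1-yl in this assay gives a 1.8-fold lower number from compound 2 to compound 4 (0.25 log units; within the scatter). Set beside the earlier step, this one differs from it by no more than repeated measurements would: the same change on two cores in this assay, a 1.2-fold higher number (0.07 log units; within the scatter) from compound 1 to compound 3 and a 1.8-fold lower number (0.25 log units; within the scatter) from compound 2 to compound 4, 2.1-fold (0.31 log units) apart, within the scatter of two such steps. The change therefore carries across these two cores with no difference that can be told from scatter, but two pairs, each within the scatter, cannot show that it has no effect or that it would behave alike on any other core.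

The compounds shown leave open what propyl or benzyl in place of the ethyl would do. They also leave open whether any such change would move the number beyond the scatter.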